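Removing a Chloro Group on Two Different Cores

A few compounds are considered here, and "the series" means these few. Any claim that something is new, unique, unknown or untested is made for them only; others in the source may bear on it.

Compound 1 `CNC(=O)c1cc(C(=O)N[C@H]2CC[C@H](O)CC2)c([C@@H](C)c2ccccc2Cl)o1` and compound 2 `CNC(=O)c1cc(C(=O)N[C@H]2CC[C@H](O)CC2)c([C@@H](C)c2ccccc2)o1` share one core and differ by hydrogen in place of chloro on an aromatic carbon. In an ADME assay for permeability (a lower number here means that the compound crosses the layer more slowly, a higher number that the compound crosses the layer faster), compound 1 gives 78 nm/s, while compound 2 gives 42 nm/s, a step of a 1.9-fold lower number from compound 1 to compound 2 (0.27 log units; within the scatter).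

Compound 3 `CNC(=O)c1cc(C(=O)N[C@H]2[C@@H]3C[C@@H](O)C[C@@H]32)n([C@@H](C)c2cccc(Cl)c2)n1` is built on another core; the difference between the two cores is not broken down here. In this assay compound 3 gives 197 nm/s, the highest of the three measured numbers, with its steps to both other compounds beyond the scatter.

Compound 4 `CNC(=O)c1cc(C(=O)N[C@H]2[C@@H]3C[C@@H](O)C[C@@H]32)n([C@@H](C)c2ccccc2)n1` is related to compound 3 by hydrogen in place of chloro on an aromatic carbon. This is the same kind of change as the one from compound 1 to compound 2, and it occurs twice among the compounds shown, but the place differs: the chloro that leaves sits ortho to a large group in compound 1 and meta to a large group in compound 3. The expectation for compound 4 rests on compound 3 with 197 nm/s and on the earlier step of a 1.9-fold lower number from compound 1 to compound 2 (0.27 log units; within the scatter). The expected step is a 1.9-fold lower number from compound 3 to compound 4 (0.27 log units; within the scatter). Compound 4 is therefore estimated to give 105 nm/s, most likely between 55 nm/s and 200 nm/s.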

Compound 4, apparent permeability: 61 nm/s
For compound 4 the middle estimate is 1.7-fold (0.24 log units) above the measured one; the measured number falls inside the stated range.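

In this assay, putting hydrogen in place of chloro gives a 3.2-fold lower number from compound 3 to compound 4 (0.51 log units; beyond the scatter), a step that can be read beyond the scatter on this core. Set beside the earlier pair, the change points the same way on both cores, and the sizes of the two steps cannot be told apart, so the result on one core was a fair guide to the result on the other: the same change on two cores in this assay, a 1.9-fold lower number (0.27 log units; within the scatter) from compound 1 to compound 2 and a 3.2-fold lower number (0.51 log units; beyond the scatter) from compound 3 to compound 4, 1.7-fold (0.24 log units) apart, within the scatter of two such steps. Among these compounds, this rests on only two pairs, with the chloro in a different place on the ring in each, so it does not show that the step has one fixed size across the series, nor does it explain why the number falls.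

The compounds shown leave open whether a chloro in the same place on both cores would give matching steps. They also leave open how a fluoro, methyl or methoxy group in that place would compare with chloro and hydrogen on either core.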